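This account rests on a few compounds, and the source may have more. Where it says the series, first, only, none or still open, it means among the compounds named here.

The series shares one core, seen in compound 1 `CCCC[C@H](CC)C[C@]1(CC)C=C(CC)/C(=C/C(=O)OC)O1`. In a functional assay on A549 cells (Homo sapiens) for cytotoxicity, read by MTT assay, with a stated time of 72 h (a lower number here means a stronger inhibitor, a higher number a weaker inhibitor), compound 1 gives only a limit of the assay, > 100000 nM. Compound 2 `CCCCC(C)C[C@]1(CC)O[C@H]1[C@]1(CC)C=CC(=O)O1` is the second measured member. In this assay compound 2 also returns only a limit, > 100000 nM. Compound 3 `CCCCC(C)Cc1cc(CC)c(CC(=O)O)o1` is the third. In this assay compound 3 likewise sits at a limit, > 100000 nM. All three measured values therefore stand at the limit of > 100000 nM in this assay, at which 3 of the 3 values shown sit, and compound 1 can be placed only at that limit, as the other two are, with no number to rank it.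

Compound 4 `CC/C=C/[C@H](CC)C[C@]1(CC)C=C(CC)/C(=C/C(=O)OC)O1` differs from compound 1 in one place: but-1-en-1-yl in place of butyl on a saturated chain carbon bound to two saturated chain carbons. Within the data shown here, no step between two measured compounds is available to calibrate this change. Because every value shown sits at the limit of > 100000 nM in this assay, at which 3 of the 3 values shown sit, no step beyond the scatter is expected, and the step from compound 1 to compound 4 is estimated as a step that the limit leaves unreadable from compound 1 to compound 4. Compound 4 is expected to remain at the limit, with an estimate of 150000 nM and a range from 50000 nM to 500000 nM.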

Compound 4, half-maximal inhibitory concentration: > 100000 nM
Compound 4: only a limit was reported (the forecaster's own chance of this, stated with the estimate: 85%); the middle value does not contradict the limit.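

No step can be read from compound 1 to compound 4, because both stand only at a limit of the assay: the limit of > 100000 nM in this assay, at which 4 of the 4 values shown sit.

The compounds shown leave open whether any change to the shared core gives a measurable value in this assay and how butyl and but-1-en-1-yl compare there.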